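The source may report more compounds than this note shows. Statements on the series, on what has been measured and on what is new or still open speak of the compounds shown alone.

Measured so far:
compound 1 `Cc1ccc(S(=O)(=O)c2cc3cnc(Nc4ccc5[nH]ccc5c4)nc3n(C)c2=O)cc1` — 750 nM
compound 2 `Cc1ccc(S(=O)(=O)c2cc3cnc(Nc4ccc5cc[nH]c5c4)nc3n(C)c2=O)cc1` — 15000 nM
compound 3 `Cc1ccc(S(=O)(=O)c2cc3cnc(Nc4cnc5c(c4)CC(=O)N5)nc3n(C)c2=O)cc1` — 15000 nM

In a functional assay on DU-145 cells (Homo sapiens) for inhibition, read by trypan blue exclusion, with a stated time of 72 h (on this read-out higher numbers stand for weaker inhibition and lower numbers for stronger inhibition), compound 1 stands lowest of the three, which on this read-out means the strongest inhibition: a 20-fold higher number from compound 1 to compound 2 (1.30 log units; beyond the scatter), and a 20-fold higher number from compound 1 to compound 3 (1.30 log units; beyond the scatter). Compound 4 `Cn1c(=O)c(S(=O)(=O)c2ccc(N)cc2F)cc2cnc(Nc3ccc4[nH]ccc4c3)nc21` is not yet measured. It differs from compound 1 in one place: 4-amino-2-fluorophenyl in place of 4-methylphenyl on a sulfonyl sulfur. Among the measured compounds shown here, both measured steps change the group on the nitrogen on the aromatic ring and leave the sulfonyl side untouched, so no measured step bears on this change, and its size and direction are unknown. Compound 4 is therefore expected to land close to compound 1, with no change at the digits printed from compound 1 to compound 4 (within the scatter) as the expected step, not beyond the scatter, but with a wide margin. The estimate for compound 4 is 750 nM, expected to fall between 150 nM and 4000 nM.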

Compound 4, half-maximal inhibitory concentration: 8000 nM
Compound 4: the middle estimate sits 11-fold (1.03 log units) below what was measured; measured number outside the range, above it.
By their numbers in this assay, from the lowest: compound 1; then compounds 4, 2 and 3 (each within the scatter of the next).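

In this assay, 4-amino-2-fluorophenyl in place of 4-methylphenyl on the sulfonyl sulfur gives an 11-fold higher number from compound 1 to compound 4 (1.03 log units; beyond the scatter) and so counts as a large step. The earlier compounds shown here changed only the group on the nitrogen, which makes this the first sign that the sulfonyl side also moves the number. Still open, going by these compounds, is whether the amino group or the fluorine carries this step, which 4-aminophenyl or 2-fluorophenyl on the same sulfur would separate. Nothing shown here accounts for the size of the step.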